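Dropping one butanoyl ester from a cytosine nucleoside diester

The compounds below may be only part of what the source reports. "The series", "measured", "known", "first", "only" and "open" are said of these compounds alone.

Compound 1 `CCCC(=O)OC[C@H]1O[C@@H](n2ccc(N)nc2=O)[C@@H](O)[C@@H]1OC(=O)CCC` is tested in a functional assay on HeLa cells (Homo sapiens) for cytotoxicity, read by cell counting, with a stated time of 48 h (on this read-out higher numbers stand for an effect only at larger amounts of compound and lower numbers for an effect already at smaller amounts), where compound 1 gives 0.11 ug/mL. Compound 2 `CCCCCCCCCC(=O)OC[C@H]1O[C@@H](n2ccc(N)nc2=O)[C@@H](O)[C@@H]1O` gives 0.1 ug/mL in this assay, so the two sit together within the usual scatter and no ranking between them can be read. Compound 3 `CCCC(=O)O[C@H]1[C@H](O)[C@H](n2ccc(N)nc2=O)O[C@@H]1CO` arises from compound 1 by hydrogen in place of propylcarbonyl on an oxygen on a saturated carbon. Within the data shown here, no measured pair shows this change. Since compound 2 carries a single ester on the shared core and gives 0.1 ug/mL, the step from compound 1 to compound 3 is expected to be a 1.4-fold higher number from compound 1 to compound 3 (0.13 log units; within the scatter), staying within the scatter. Compound 3 is estimated at 0.15 ug/mL, with a range from 0.05 ug/mL to 0.5 ug/mL.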

Compound 3, concentration for half-maximal effect: 0.11 ug/mL
For compound 3 the middle estimate is 1.4-fold (0.13 log units) above the measured one; the range from low to high includes it.
By their numbers in this assay, from the lowest: compounds 2, 1 and 3 (each within the scatter of the next).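

Among these compounds, this is the first measured case of hydrogen in place of propylcarbonyl on this oxygen, and it reads as no change at the digits printed from compound 1 to compound 3 (within the scatter). At this position, ((propylcarbonyl)oxy)methyl and hydroxymethyl cannot be told apart in this assay, so this ester of compound 1 is dispensable for the read-out. No measurement on hand offers a reason for this.

The compounds shown leave open how an amine or a carboxylic acid would read at this position. They also leave open whether the value would hold with hydrogen in place of the remaining propylcarbonyl of compound 3.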